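Thiophene for furan on a weakly active nucleoside

The source may report more compounds than this note shows. Statements on the series, on what has been measured and on what is new or still open speak of the compounds shown alone.

Compound 1 `COc1nc(N)nc2c1c(-c1ccoc1)cn2[C@@H]1O[C@H](CO)[C@@H](O)[C@H]1O`: > 20000 nM (a limit)
Compound 2 `Nc1nc2c(c(-c3ccoc3)cn2[C@@H]2O[C@H](CO)[C@@H](O)[C@H]2O)c(=O)[nH]1`: 19600 nM

Both compounds were tested in a functional assay on K562 cells (Homo sapiens), read by MTT assay, with a stated time of 72 h; on this read-out lower numbers stand for stronger inhibition and higher numbers for weaker inhibition. In this assay, within the data shown here, compound 2 gives 19600 nM, the only true number available so far. The result for compound 1 is a limit of the assay, > 20000 nM. The two results therefore cannot be ranked against each other.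

Compound 3 `Nc1nc2c(c(-c3ccsc3)cn2[C@@H]2O[C@H](CO)[C@@H](O)[C@H]2O)c(=O)[nH]1` keeps the core of compound 2, with thiophen-3-yl in place of furan-3-yl on an aromatic carbon. Among the measured compounds shown here, no measured pair shows a comparable swap, so the data give no direct guide. In this assay, no step beyond the scatter is expected. The estimated step of a 1.1-fold lower number from compound 2 to compound 3 (0.04 log units; within the scatter) reflects that expectation. For compound 3 the expected value is 18000 nM, with an estimated range of 8000 nM to 40000 nM.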

Compound 3, half-maximal inhibitory concentration: > 20000 nM
Compound 3 ended at the assay's limit; the forecaster's own chance of this, stated with the estimate: 55%; at least 1.1-fold (0.04 log units) between middle value and limit.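

In this assay, thiophen-3-yl in place of furan-3-yl on this aromatic carbon gives an at least 1.0-fold higher number from compound 2 to compound 3 (0.00 log units; that floor lies within the scatter). This is the first change shown at this position, and replacing the oxygen of the five-membered aromatic ring with sulfur brings no sign of stronger inhibition. Compound 3 gives > 20000 nM, which is a limit and not a number, and the true size of the step stays unknown because of that limit: the limit of > 20000 nM in this assay, at which 2 of the 3 values shown sit.

The compounds shown leave open whether any group on this carbon can bring the read-out clearly below the limit, for example a phenyl ring, an amine or a longer carbon chain. They also leave open how far compound 3 lies from compound 2, and whether the group at this position matters at all in these cells.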